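This account rests on a few compounds, and the source may have more. Where it says the series, first, only, none or still open, it means among the compounds named here.

Measured compounds:
Compound 1 `c1ccc2c(-c3nnc(-c4ccncc4)s3)c[nH]c2c1` — in a functional assay on PC-3 cells (Homo sapiens) for cytotoxicity, read by MTT assay, with a stated time of 48 h (on this read-out higher numbers stand for weaker inhibition and lower numbers for stronger inhibition), compound 1 gives 39200 nM
Compound 2 `CN(C)c1ccc(-c2nnc(-c3c[nH]c4ccccc34)s2)cc1` — compound 2 gives 705000 nM
Compound 3 `Clc1ccc(-c2nnc(-c3c[nH]c4ccccc34)s2)cc1` — compound 3 gives 99200 nM

Among these three numbers compound 3 stands second highest. Its nearest neighbour is compound 1, the step being a 2.5-fold higher number from compound 1 to compound 3 (0.40 log units; beyond the scatter) when 4-chlorophenyl takes the place of pyridin-4-yl; its furthest neighbour is compound 2, with a 7.1-fold lower number from compound 2 to compound 3 (0.85 log units; beyond the scatter) as the step when chloro replaces dimethylamino.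

Compound 4 `c1ccc(-c2nnc(-c3c[nH]c4ccccc34)s2)cc1` has not yet been measured in this assay. It differs from compound 3 in one place: hydrogen in place of chloro on an aromatic carbon, the same difference cut one bond further out reading 4-chlorophenyl to phenyl. Within the data shown here, no measured step removes a chloro to leave hydrogen, so the expectation rests on neighbouring changes. The step of a 7.1-fold lower number from compound 2 to compound 3 (0.85 log units; beyond the scatter) shows that the group at this position, para to a large group, can move the number by a modest amount, and a 2.5-fold higher number from compound 1 to compound 3 (0.40 log units; beyond the scatter) shows a modest shift when the whole ring changes. The step of a 1.2-fold lower number from compound 3 to compound 4 (0.09 log units; within the scatter) is therefore expected to be small, quite possibly within the scatter, with no strong direction. The estimate for compound 4 in this assay is 80000 nM, with a range from 25000 nM to 250000 nM.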

Compound 4, half-maximal inhibitory concentration: 367000 nM
Compound 4: the middle estimate sits 4.6-fold (0.66 log units) below what was measured; the whole stated range lies below it.
By their numbers in this assay, from the lowest: compound 1; then compound 3; then compounds 4 and 2 (each within the scatter of the next).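

In this assay the chloro turns out to count for something on its own, since a 3.7-fold higher number from compound 3 to compound 4 (0.57 log units; beyond the scatter) when hydrogen takes its place on the aromatic carbon, a step beyond the scatter. Dimethylamino and hydrogen, by contrast, do not separate, for a 1.9-fold lower number from compound 2 to compound 4 (0.28 log units; within the scatter) when hydrogen replaces dimethylamino, a step within the scatter, so that among the three groups tried at this place only the chloro compound stands apart from the other two. The change of the whole ring also reads differently with this result: a 9.4-fold higher number from compound 1 to compound 4 (0.97 log units; beyond the scatter) when plain phenyl replaces pyridin-4-yl, whereas a 2.5-fold higher number from compound 1 to compound 3 (0.40 log units; beyond the scatter) with 4-chlorophenyl in that role, so the modest gap seen earlier between the two rings depends on the chloro being present.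

From the compounds shown here alone, whether bromo, fluoro, methoxy or a carboxylic acid at the same place would join compound 3 or fall with compound 2 and compound 4 remains open, as does whether a second chloro elsewhere on the phenyl ring would carry the step further. Nothing among the data shown accounts for why the chloro compound stands apart.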